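Two flipped ring stereocentres, same atoms and bonds

The source may hold more compounds than are shown below. What is called first, only, known or untested is meant among the compounds shown, and "the series" means these compounds.

In an ADME assay on Caco-2 cells (Homo sapiens) for permeability, read by LC-MS, in the apical to basolateral direction, with a stated time of 60 min, at pH 6.5 (a lower number here means that the compound crosses the layer more slowly, a higher number that the compound crosses the layer faster), compound 1 (`CC(C)(C)OC[C@@H](O)C(=O)N1[C@H](C(=O)NCc2cc(Cl)ccc2-n2cnnn2)C[C@@H]2C[C@@H]21`) gives 4.5 10^-6 cm/s and compound 2 (`CC(C)(C)C[C@@H](O)C(=O)N1[C@@H]2C[C@@H]2C[C@H]1C(=O)NCc1cc(Cl)ccc1-n1cnnn1`) gives 24 10^-6 cm/s as the higher of the two numbers, a gap beyond the usual scatter. For the measured compounds named here, compound 3 (`CC(C)(C)C[C@@H](O)C(=O)N1[C@H](C(=O)NCc2cc(Cl)ccc2-n2cnnn2)C[C@@H]2C[C@@H]21`) departs from compound 2 by the two compounds have the same atoms and bonds and differ only in configuration as drawn: 2 of 4 stereo elements differ; a stereocentre at a saturated ring carbon is drawn R in compound 2 and S in compound 3; a stereocentre at a saturated ring carbon is drawn R in compound 2 and S in compound 3 in configuration only, with two saturated ring carbons drawn S rather than R. No measured pair shows a change of this kind on its own. The expected change is a 1.3-fold lower number from compound 2 to compound 3 (0.12 log units; within the scatter) in this assay and would stay within the scatter, with a modest drop the likelier direction. For compound 3 the estimate is 18 10^-6 cm/s with an expected range of 7 10^-6 cm/s to 40 10^-6 cm/s in this measurement.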

Compound 3, apparent permeability: 25 10^-6 cm/s
The estimate for compound 3 lay 1.4-fold (0.14 log units) below the measured number; the measured number falls inside the stated range.
By their numbers in this assay, from the lowest: compound 1; then compounds 2 and 3 (each within the scatter of the next).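

In this assay, flipping the two saturated ring carbons gives a 1.0-fold higher number from compound 2 to compound 3 (0.02 log units; within the scatter), so the two configurations cannot be told apart by this read-out. The structures leave a single difference to consider: the fact that compounds 2 and 3 differ only in the configuration as drawn With the ring configuration now held constant, tert-butyl in place of tert-butoxy gives a 5.6-fold higher number from compound 1 to compound 3 (0.74 log units; beyond the scatter), a change in one place that the earlier pair, which differed in more than one, could not isolate.

From the compounds shown here alone, the two stereocentres that stayed the same remain untested, so their configuration may or may not matter. Going by these compounds, it also remains open how an amine or a carboxylic acid would read at the tert-butyl position.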